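The compounds below may be only part of what the source reports. "The series", "measured", "known", "first", "only" and "open" are said of these compounds alone.

Among the compounds with values here, compound 2 `Cc1nc(-c2ccc(C(F)(F)F)cc2)sc1CNc1ccc(/C=C/C(=O)O)cc1` gives 36.3 nM in a functional assay on CHO cells for agonist activity at Free fatty acid receptor 1 (Homo sapiens) (a higher number here means that more compound is needed for the effect, a lower number that less compound is needed), the lower of the two numbers measured so far; compound 1 `O=C(O)CCCc1ccc(NCc2cccc(Oc3ccccc3)c2)cc1` gives 1120 nM, a gap beyond the scatter. Compound 3 `Cc1nc(-c2ccc(C(F)(F)F)cc2)sc1CNc1ccc([C@H]2C[C@@H]2C(=O)N(C)C)cc1` has not yet been measured. It differs from compound 2 in one place: 2-(dimethylcarbamoyl)cyclopropyl in place of 2-carboxyethenyl on an aromatic carbon, on an aromatic carbon para to a large group. Within the data shown here, no measured pair shows a change of this kind, so the expectation rests on the change alone. In this assay a marked rise is expected, an 83-fold higher number from compound 2 to compound 3 (1.92 log units; beyond the scatter). For compound 3 the estimate is 3000 nM, within 300 nM to 30000 nM.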

Compound 3, half-maximal effective concentration: 66.1 nM
For compound 3 the middle estimate is 45-fold (1.66 log units) above the measured one, outside the stated range (below it).
By their numbers in this assay, from the lowest: compounds 2 and 3 (each within the scatter of the next); then compound 1.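

In this assay, a 1.8-fold higher number from compound 2 to compound 3 (0.26 log units; within the scatter). At this position, on an aromatic carbon para to a large group, the swap therefore leaves the number within the scatter, even though 2-carboxyethenyl has a hydrogen-bond donor and 2-(dimethylcarbamoyl)cyclopropyl has none. No data shown here explain this result. As far as these compounds go, both the linker and the end group changed in this one step, so their separate contributions stay open. A 2-carboxycyclopropyl group or a 2-(dimethylcarbamoyl)ethenyl group at the same place would separate the two.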